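The source may hold more compounds than are shown below. What is called first, only, known or untested is meant among the compounds shown, and "the series" means these compounds.

In a functional assay on UO-31 cells (Homo sapiens) for inhibition, read by sulforhodamine B assay, with a stated time of 48 h, tested at 10 uM (on this read-out higher numbers stand for a weaker effect at the one concentration tested and lower numbers for a stronger effect), compound 1 `COc1cc2cc(Oc3ccc(NC(=O)Nc4ccc(C)cc4)cc3)c(C)nc2cc1OC` gives 89.2%, while compound 2 `COc1cc2cc(Oc3ccc(NC(=O)Nc4ccc(Cl)c(C(F)(F)F)c4)cc3)c(C)nc2cc1OC` gives -45.1%. Among the measured compounds shown here, the one measured step, a number 134.3 percentage points lower from compound 1 to compound 2 (beyond the scatter), is large and leaves compound 2 with the lowest of the two numbers. Compound 3 `COc1cc2cc(Oc3ccc(NC(=O)Nc4ccc(Cl)c(Cl)c4)cc3)c(C)nc2cc1OC` differs from compound 2 in a single place: chloro in place of trifluoromethyl on an aromatic carbon. For the measured compounds named here, no measured step touches this part of the structure, so that large step serves only as a loose guide; a modest shift within the scatter, in either direction, is expected, a number 15.1 percentage points higher from compound 2 to compound 3 (beyond the scatter). Compound 3 is therefore estimated to give -30% in this assay, between -75% and 25%.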

Compound 3, a percentage reported as activity, at one concentration (the size of the read-out at that concentration, not a potency): 3.69%
Beside the measured number, compound 3's estimate is 33.7 percentage points below it, and the stated range covers the measured number.
By their numbers in this assay, from the lowest: compound 2; then compound 3; then compound 1.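

In this assay, the aromatic carbon ortho to the chloro group proves sensitive to what it carries: chloro in place of trifluoromethyl gives a number 48.8 percentage points higher from compound 2 to compound 3 (beyond the scatter). A 3,4-dichlorophenyl group in place of 4-methylphenyl still gives a number 85.5 percentage points lower from compound 1 to compound 3 (beyond the scatter), so the large drop does not depend on trifluoromethyl alone, although that group gives the lowest number. No measurement at hand explains why these groups differ. Open, going by these compounds, is how a nitrile, a methoxy group or an amine on this carbon would read, and whether any would go lower than trifluoromethyl.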